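Replacing a Hydroxy with Ethyl on an Alkyne Chain

The compounds below may be only part of what the source reports. "The series", "measured", "known", "first", "only" and "open" are said of these compounds alone.

Of the compounds shown here, two have been tested in an ADME assay on L1210/0 cells (Mus musculus) for cytotoxicity, with a stated time of 48 h; on this read-out lower numbers stand for stronger inhibition and higher numbers for weaker inhibition. Compound 1 `COc1ccccc1-c1ncnc2c1ncn2C[C@@H]1C[C@H](O)c2ccccc21` reached only the assay limit, giving > 200000 nM. Compound 2 `O=c1[nH]c(=O)n([C@H]2C[C@H](O)[C@@H](CO)O2)cc1C#CCCCO` likewise reached only the limit, giving > 200000 nM. So compound 2 stands where every value shown stands: at the limit of > 200000 nM in this assay, at which 2 of the 2 values shown sit. Compound 3 `CCCCCC#Cc1cn([C@H]2C[C@H](O)[C@@H](CO)O2)c(=O)[nH]c1=O` differs from compound 2 as follows: ethyl in place of hydroxy on a saturated chain carbon, three bonds along the chain from a triple-bonded carbon. Among the measured compounds shown here, with no measured step available, no change beyond the usual scatter is expected in this assay, and the step of a number no higher from compound 2 to compound 3 (the limit leaves the size open) is expected to keep compound 3 near the limit. Compound 3 is therefore estimated at 200000 nM, within 60000 nM to 600000 nM.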

Compound 3, half-maximal inhibitory concentration: > 200000 nM
Compound 3: a limit, no number; the forecaster's own chance of this, stated with the estimate: 80%; the middle value sits exactly at the limit.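

No step can be read from compound 2 to compound 3, because both values are limits and not numbers: the limit of > 200000 nM in this assay, at which 3 of the 3 values shown sit.

The compounds shown leave open whether ethyl in place of hydroxy changes cytotoxicity at all, and what change would bring a measurable value.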